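The source may hold more compounds than are shown below. What is called first, only, known or untested is meant among the compounds shown, and "the series" means these compounds.

Measured compounds:
- compound 1 `Cc1cc(Cl)ccc1NC(=O)Nc1nc(Sc2c[nH]c3ccccc23)cc(N2CCN(Cc3ccccc3)CC2)n1`: 22500 nM
- compound 2 `COc1ccc(NC(=O)Nc2nc(Sc3c[nH]c4ccccc34)cc(N3CCN(c4ccccn4)CC3)n2)cc1`: 33400 nM
- compound 3 `O=C(Nc1ccccc1)Nc1nc(Nc2ccccc2)cc(Sc2c[nH]c3ccccc23)n1`: 26400 nM

All three numbers come from a functional assay on PC-3 cells (Homo sapiens) for inhibition, with a stated time of 72 h; a lower number here means a stronger inhibitor, a higher number a weaker inhibitor. Compound 2 has the highest of the three numbers, but its gap to compound 3 and its gap to compound 1 both lie within the scatter of the method, so the three cannot be told apart. Compound 4 `COc1ccc(NC(=O)Nc2nc(Sc3c[nH]c4ccccc34)cc(N3CCCC3)n2)cc1` differs from compound 2 in one place: pyrrolidin-1-yl in place of 4-(pyridin-2-yl)piperazin-1-yl on an aromatic carbon. Within the data shown here, no measured pair carries this change. The three measured compounds carry different groups at this position and still sit within the scatter of one another, which gives no ground for expecting a step in this assay beyond the scatter in either direction. Compound 4 is therefore estimated at 30000 nM, with a range of 10000 nM to 90000 nM. The step this estimate implies is a 1.1-fold lower number from compound 2 to compound 4 (0.05 log units; within the scatter).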

Compound 4, half-maximal inhibitory concentration: 21500 nM
Beside the measured number, compound 4's estimate is 1.4-fold (0.14 log units) above it; measured number inside the range.
By their numbers in this assay, from the lowest: compounds 4, 1, 3 and 2 (each within the scatter of the next).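

In this assay, among these compounds, pyrrolidin-1-yl in place of 4-(pyridin-2-yl)piperazin-1-yl gives a 1.6-fold lower number from compound 2 to compound 4 (0.19 log units; within the scatter) and provides the first direct one-place comparison at this position. On this aromatic carbon, removing both the piperazine and pyridine rings leaves the two compounds within the scatter. No measurement available here bears on the reason for this result.

From the compounds shown here alone, it remains open whether a primary amine, a morpholin-4-yl group or a carboxylic acid on this carbon would give a step beyond the scatter.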